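Shifting the chlorophenyl position across two cores

A few compounds are considered here, and "the series" means these few. Any claim that something is new, unique, unknown or untested is made for them only; others in the source may bear on it.

Measured so far:
compound 1 `O=C1/C(=C/c2ccccc2F)CN(C(=S)SCc2cn(Cc3ccccc3Cl)nn2)C/C1=C\c1ccccc1F`: 43600 nM
compound 2 `COc1ccc(/C=C2\CN(C(=S)SCc3cn(Cc4cccc(Cl)c4)nn3)C/C(=C\c3ccc(OC)cc3)C2=O)cc1`: 69700 nM
compound 3 `O=C1/C(=C/c2ccccc2F)CN(C(=S)SCc2cn(Cc3cccc(Cl)c3)nn2)C/C1=C\c1ccccc1F`: a limit only

In a functional assay on 4T1 cells (Mus musculus) for cytotoxicity, read by MTT assay, with a stated time of 24 h (a lower number here means a stronger inhibitor, a higher number a weaker inhibitor), compound 1 gives 43600 nM and compound 2 gives 69700 nM. For compound 3 the assay returns only a limit, > 100000 nM. The change 2-chlorophenyl in place of 3-chlorophenyl on a saturated chain carbon bound to an aromatic nitrogen produces an at least 2.2-fold lower number from compound 3 to compound 1 (0.36 log units; beyond the scatter), a step whose size is bounded by the limit of > 100000 nM in this assay, at which 1 of the 3 values shown sits. The difference between the cores of compound 2 and compound 3 is not broken down here. Compound 4 `COc1ccc(/C=C2\CN(C(=S)SCc3cn(Cc4ccccc4Cl)nn3)C/C(=C\c3ccc(OC)cc3)C2=O)cc1` is not yet measured; it carries the same change on the core of compound 2, (2-chlorophenyl in place of 3-chlorophenyl on a saturated chain carbon bound to an aromatic nitrogen), with the place worded identically, so it is the same change. Because compound 2 gives 69700 nM and the measured change gave an at least 2.2-fold lower number from compound 3 to compound 1 (0.36 log units; beyond the scatter), a step of about a 2.3-fold lower number from compound 2 to compound 4 (0.37 log units; beyond the scatter) is expected. The estimate for compound 4 is 30000 nM, expected between 12000 nM and 75000 nM.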

Compound 4, half-maximal inhibitory concentration: > 100000 nM
Compound 4 gave a limit, no number; the forecaster's own chance of this, stated with the estimate: 5%; middle value at least 3.3-fold (0.52 log units) from the limit.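

In this assay, 2-chlorophenyl in place of 3-chlorophenyl does not carry over as one step from core to core: the same change on two cores in this assay, an at least 2.2-fold lower number (0.36 log units; beyond the scatter) from compound 3 to compound 1 and an at least 1.4-fold higher number (0.15 log units; that floor lies within the scatter) from compound 2 to compound 4, at least 3.2-fold (0.51 log units) apart, beyond the scatter of two such steps. Compound 4 returned only a limit, > 100000 nM. The new step, an at least 1.4-fold higher number from compound 2 to compound 4 (0.15 log units; that floor lies within the scatter), is a floor and not a full size, so the true size of the change on this core stays unknown, and two cores give no rule for any other core or any reason for the gap.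

Open, as far as these compounds go, is whether the same divergence appears on a third core. Also open, from the compounds shown here alone, is whether a pyridyl ring or a longer chain in place of the chlorophenyl gives full numbers on both cores.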